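The source may hold more compounds than are shown below. What is called first, only, known or untested is meant among the compounds shown, and "the series" means these compounds.

Measured compounds:
- compound 1, `CC1(C)CC(=O)N(c2ccccc2C(=O)OCC2CCCN(CCCc3ccccc3)C2)C1=O`, 7500 nM
- compound 2, `CC1C(=O)N(c2ccccc2C(=O)OCC2CCCN(CCCc3ccccc3)C2)C(=O)C1C`, 6000 nM

Both were tested in a functional assay with Neuronal acetylcholine receptor; alpha3/beta4 (Homo sapiens) as the target; a higher number here means a weaker inhibitor, a lower number a stronger inhibitor. Compound 2 has the lowest of the two numbers, and its nearest neighbour is compound 1, whose number is higher by a margin within the scatter, so the two cannot be told apart. Within the data shown here, the only measured step, a 1.3-fold lower number from compound 1 to compound 2 (0.10 log units; within the scatter), moved one methyl from one ring position to another and changed nothing beyond the scatter.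

Compound 3, `CCC1CC(=O)N(c2ccccc2C(=O)OCC2CCCN(CCCc3ccccc3)C2)C1=O`, is not yet measured. It differs from compound 2 in this way: a group of 9 heavy atoms (6 carbon, 1 nitrogen, 2 oxygen; one five-membered non-aromatic ring with 1 hetero atom) in place of a group of 9 heavy atoms (6 carbon, 1 nitrogen, 2 oxygen; one five-membered non-aromatic ring with 1 hetero atom), on an aromatic carbon; the two have the same atoms, joined differently, and the change sits on an aromatic carbon, ortho to a large group. Since the comparable step from compound 1 to compound 2 stayed within the scatter, the step of a 1.1-fold higher number from compound 2 to compound 3 (0.03 log units; within the scatter) is expected to be small as well, with no direction beyond the scatter. Compound 3 is therefore estimated at 6500 nM, with a range from 3000 nM to 14000 nM.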

Compound 3, half-maximal inhibitory concentration: 4500 nM
The estimate for compound 3 lay 1.4-fold (0.16 log units) above the measured number, and the stated range covers the measured number.
By their numbers in this assay, from the lowest: compounds 3, 2 and 1 (each within the scatter of the next).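

Rearranging the same atoms on this aromatic carbon again makes no clear difference in this assay: the result is a 1.3-fold lower number from compound 2 to compound 3 (0.12 log units; within the scatter), and the wider comparison is a 1.7-fold lower number from compound 1 to compound 3 (0.22 log units; within the scatter), with both steps within the scatter. Compound 1, compound 2 and compound 3 therefore cannot be told apart, so across these three arrangements the assay does not distinguish how the carbons are placed on the five-membered ring. No supporting evidence is available to explain this result.

All three compounds carry the same atoms in this group, so they test only rearrangement and not a change in what the group contains. As far as these compounds go, whether a longer chain on the ring, an amine or a carboxylic acid would move the number beyond the scatter remains open.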